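Amide side chain variants on the shared core

The source may report more compounds than this note shows. Statements on the series, on what has been measured and on what is new or still open speak of the compounds shown alone.

Measured so far in a functional assay on the whole organism (Tail, strain ICR) with Mus musculus as the target, in the tail flick test, with a stated time of 60 min, at a dose of 25 umol/kg by the oral route; a higher number here means a stronger effect of the compound at the dose given, a lower number a weaker effect:
compound 1, `CC[C@H](C)[C@H](NC(=O)CN(c1nc(Cl)nc2[nH]cnc12)C1CC1)C(=O)OCc1ccccc1`, gives 40.6%;
compound 2, `O=C(CN(c1nc(Cl)nc2[nH]cnc12)C1CC1)NCC(=O)OCc1ccccc1`, gives 41.9%;
compound 3, `NC(=O)CC[C@H](NC(=O)CN(c1nc(Cl)nc2[nH]cnc12)C1CC1)C(=O)OCc1ccccc1`, gives 33.1%.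

Compound 3 carries the lowest of the three numbers, but its gap to compound 1 and to compound 2 stays within the scatter, so no order among the three can be read. Compound 4, `O=C(CN(c1nc(Cl)nc2[nH]cnc12)C1CC1)N[C@@H](CO)C(=O)OCc1ccccc1`, differs from compound 3 by hydroxy in place of carbamoylmethyl on a saturated chain carbon, two bonds along the chain from an amide-type nitrogen and a carbonyl carbon. Within the data shown here, the steps that bear on this place are a number 7.5 percentage points lower from compound 1 to compound 3 (within the scatter) and a number 8.8 percentage points lower from compound 2 to compound 3 (within the scatter); both alter the side chain on the saturated chain carbon bound to an amide-type nitrogen and a carbonyl carbon, and neither moves the read-out beyond the scatter. Among the measured compounds shown here, a hydroxy group here has no measured precedent, so the expectation is for no step beyond the scatter, written as a number 4.9 percentage points higher from compound 3 to compound 4 (within the scatter). For compound 4 the estimate is 38%, with a range from 27% to 49%.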

Compound 4, a percentage reported as activity, at one dose (the size of the read-out at that dose, not a potency): 34.2%
Beside the measured number, compound 4's estimate is 3.8 percentage points above it; the range from low to high includes it.
By their numbers in this assay, from the lowest: compounds 3, 4, 1 and 2 (each within the scatter of the next).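

In this assay hydroxymethyl on the saturated chain carbon bound to an amide-type nitrogen and a carbonyl carbon gives a number 1.1 percentage points higher from compound 3 to compound 4 (within the scatter) and a number 7.7 percentage points lower from compound 2 to compound 4 (within the scatter) and a number 6.4 percentage points lower from compound 1 to compound 4 (within the scatter). Hydroxymethyl thus joins hydrogen, sec-butyl and 2-carbamoylethyl at this position, and the read-out separates none of the four. No measurement at hand offers an explanation for this result. Open, going by these compounds, is whether an amine, a carboxylic acid or a longer chain at this position would give a step beyond the scatter.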